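A few compounds are considered here, and "the series" means these few. Any claim that something is new, unique, unknown or untested is made for them only; others in the source may bear on it.

Compound 2 `COc1ccc(-c2nc(SCC(=O)c3sc(-c4ccccc4)nc3C)[nH]c(=O)c2C#N)cc1OC` — 63700 nM
Compound 1 `COc1ccc(-c2nc(C)c(C(=O)CSc3nc(N)c(C#N)c(-c4ccc(OC)cc4)n3)s2)cc1` — 24300 nM

Two measured compounds frame this step. In a functional assay on MCF7 cells (Homo sapiens) for antiproliferative activity, read by MTT assay, with a stated time of 48 h (on this read-out higher numbers stand for weaker inhibition and lower numbers for stronger inhibition), compound 2 gives 63700 nM, the highest of the two numbers shown, while compound 1 gives 24300 nM. The gap between them is beyond the scatter, so compound 2 is the weaker inhibitor of the pair. Compound 3 `COc1ccc(-c2nc(C)c(C(=O)CSc3nc(-c4ccc(OC)c(OC)c4)c(C#N)c(=O)[nH]3)s2)cc1` has not yet been measured in this assay. It differs from compound 2 in one place: methoxy in place of hydrogen on an aromatic carbon. Within the data shown here, no measured pair shows this same change, so its effect cannot be read from the numbers at hand. The expected step is a 1.2-fold lower number from compound 2 to compound 3 (0.06 log units; within the scatter), one that stays within or close to the scatter, with no clear direction. On that basis compound 3 is estimated to give 55000 nM, within a range from 20000 nM to 130000 nM.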

Compound 3, half-maximal inhibitory concentration: 24000 nM
Estimate against measurement, compound 3: 2.3-fold (0.36 log units) above; measured number inside the range.
By their numbers in this assay, from the lowest: compounds 3 and 1 (each within the scatter of the next); then compound 2.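

Placing methoxy on the six-membered aromatic ring of carbon only, para to a large group, gives a 2.7-fold lower number from compound 2 to compound 3 (0.42 log units; beyond the scatter) in this assay, the first reading of this change. Turning phenyl into 4-methoxyphenyl at this position therefore moves the number modestly but beyond the scatter, toward stronger inhibition, so this position is not indifferent to substitution. No measurement at hand bears on why the step occurs.

As far as these compounds go, with one pair, it remains open whether this step is particular to methoxy or would also follow from another group at the same position. An ethoxy group, a fluorine atom or an amine there would test this, and the same change on a different core would show whether the step carries over.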